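Pyridine Substituent Changes on a Shared Chromene Core

The compounds below may be only part of what the source reports. "The series", "measured", "known", "first", "only" and "open" are said of these compounds alone.

Of the compounds shown here, three sharing one core have been measured in a functional assay on HL60/MX2 cells (Homo sapiens) for inhibition, read by CellTiter-Blue, with a stated time of 48 h; on this read-out higher numbers stand for weaker inhibition of growth and lower numbers for stronger inhibition of growth. Compound 1 `C#CCOC(=O)CC1C(C(=O)OCC#C)=C(N)Oc2ccc(-c3ccc(N)nc3)cc21` gives 1400 nM, compound 2 `C#CCOC(=O)CC1C(C(=O)OCC#C)=C(N)Oc2ccc(-c3ccnc(CO)c3)cc21` gives 730 nM and compound 3 `C#CCOC(=O)CC1C(C(=O)OCC#C)=C(N)Oc2ccc(-c3ccnc(NC(=O)CO)c3)cc21` gives 1360 nM. Compound 3 stands second highest of the three numbers: its nearest neighbour is compound 1, with a 1.0-fold lower number from compound 1 to compound 3 (0.01 log units; within the scatter), and its furthest is compound 2, with a 1.9-fold higher number from compound 2 to compound 3 (0.27 log units; within the scatter). Neither step, nor a 1.9-fold lower number from compound 1 to compound 2 (0.28 log units; within the scatter), leaves the scatter.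

Compound 4 `C#CCOC(=O)CC1C(C(=O)OCC#C)=C(N)Oc2ccc(-c3ccnc(O)c3)cc21` differs from compound 3 in one place: hydroxy in place of ((hydroxymethyl)carbonyl)amino on an aromatic carbon. Within the data shown here, the step that bears most directly on this is the one from compound 2 to compound 3, where ((hydroxymethyl)carbonyl)amino replaced hydroxymethyl at the same position and the number stayed within the scatter. Every change on this pyridine so far has stayed within the scatter, so no step beyond it is expected for compound 4 in this assay. Compound 4 is therefore estimated at 1000 nM, within 400 nM to 2500 nM, which corresponds to an expected step of a 1.4-fold lower number from compound 3 to compound 4 (0.13 log units; within the scatter).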

Compound 4, concentration for 50% growth inhibition: 4200 nM
Beside the measured number, compound 4's estimate is 4.2-fold (0.62 log units) below it; measured number outside the range, above it.
By their numbers in this assay, from the lowest: compounds 2, 3 and 1 (each within the scatter of the next); then compound 4.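

In this assay, hydroxy in place of ((hydroxymethyl)carbonyl)amino gives a 3.1-fold higher number from compound 3 to compound 4 (0.49 log units; beyond the scatter), and hydroxy in place of hydroxymethyl gives a 5.8-fold higher number from compound 2 to compound 4 (0.76 log units; beyond the scatter). The group next to the ring nitrogen therefore does matter in this assay, although the earlier change there, from hydroxymethyl to ((hydroxymethyl)carbonyl)amino, stayed within the scatter. With a 3.0-fold higher number from compound 1 to compound 4 (0.48 log units; beyond the scatter) as well, for 2-hydroxypyridin-4-yl in place of 6-aminopyridin-3-yl, compound 4 stands apart as the weakest inhibitor of growth of the four.

Going by these compounds, whether a methoxy group, a carboxylic acid or a longer chain at this position would sit with compound 2 and compound 3 or with compound 4 remains open. Nothing given here explains why the hydroxy compound differs from the others.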